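Carbamoyl compound 2 and its chloro counterpart, compound 4

The compounds below may be only part of what the source reports. "The series", "measured", "known", "first", "only" and "open" are said of these compounds alone.

Measured in a functional assay on KB cells (nasopharynx, Homo sapiens) for antiproliferative activity; a lower number here means a stronger inhibitor, a higher number a weaker inhibitor:
- compound 1 `N#Cc1ccc(S(=O)(=O)Nc2cccc3c(C#N)c[nH]c23)cc1`: 33 ug/mL
- compound 2 `N#Cc1c[nH]c2c(NS(=O)(=O)c3ccc(C(N)=O)cc3)cccc12`: 15 ug/mL
- compound 3 `N#Cc1c[nH]c2c(NS(=O)(=O)c3ccc(N)cc3)cccc12`: 4.4 ug/mL

Compound 2 holds the middle of the three numbers, with a 2.2-fold lower number from compound 1 to compound 2 (0.34 log units; beyond the scatter) on one side and a 3.4-fold lower number from compound 2 to compound 3 (0.53 log units; beyond the scatter) on the other. Compound 4 `NC(=O)c1ccc(S(=O)(=O)Nc2cccc3c(Cl)c[nH]c23)cc1` has chloro in place of cyano on an aromatic carbon of the five-membered aromatic ring (chloro in place of cyano on an aromatic carbon). For the measured compounds named here, no measured step touches this place. Those above, and a 7.5-fold lower number from compound 1 to compound 3 (0.88 log units; beyond the scatter), change another group, so they suggest only a typical size, modest, and give no direction. A modest step to a lower number is expected, though tentatively. The estimated step is a 2.1-fold lower number from compound 2 to compound 4 (0.33 log units; beyond the scatter). In this assay, compound 4 is expected at 7 ug/mL, with an estimated range of 2 ug/mL to 25 ug/mL.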

Compound 4, half-maximal inhibitory concentration: 21 ug/mL
Compound 4: middle estimate off by 3.0-fold (0.48 log units), on the low side; measured number inside the range.
By their numbers in this assay, from the lowest: compound 3; then compounds 2, 4 and 1 (each within the scatter of the next, the first and the last beyond it).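

In this assay, for the compounds shown here, the first step at this position, a 1.4-fold higher number from compound 2 to compound 4 (0.15 log units; within the scatter), shows that with carbamoyl held constant, cyano and chloro on this aromatic carbon of the five-membered ring cannot be told apart. A change of this kind here therefore has no readable effect, unlike the steps among the carbamoyl, cyano and amino groups at the other site. No supporting data bear on why the two compounds read alike.

On these data alone, whether a methyl group, a bromine atom or a plain hydrogen at this carbon would also read alike remains open. So does whether cyano and chloro stay level when amino replaces carbamoyl.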